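Isopropylsulfonyl for cyclopropylsulfamoyl: an unmeasured step

A few compounds are considered here, and "the series" means these few. Any claim that something is new, unique, unknown or untested is made for them only; others in the source may bear on it.

Of the compounds shown here, two have numbers so far, and both stop at a limit. Compound 1 `CCOC(=O)[C@@H]1CCCN(S(=O)(=O)c2ccc(S(=O)(=O)N(CC)CC)cn2)C1` is the smaller of the pair. In a functional assay on MIA PaCa-2 cells (Homo sapiens) for inhibition, read by MTT assay, with a stated time of 3 days (on this read-out lower numbers stand for stronger inhibition and higher numbers for weaker inhibition), compound 1 gives only the limit of the assay, > 10000 nM. Compound 2 `CC(C)c1noc(N2CCN(C(=O)[C@@H]3CCCN(S(=O)(=O)c4ccc(S(=O)(=O)NC5CC5)cc4)C3)CC2)n1` builds the shared core out into a larger structure. In this assay compound 2 likewise gives only a limit, > 10000 nM. Where compound 2 stands is thus told by a limit alone, and the one further value shown is also a limit, both values sitting at the limit of > 10000 nM in this assay, at which 2 of the 2 values shown sit.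

Compound 3 `CC(C)c1noc(N2CCN(C(=O)[C@@H]3CCCN(S(=O)(=O)c4ccc(S(=O)(=O)C(C)C)cc4)C3)CC2)n1` differs from compound 2 in one place: isopropyl in place of cyclopropylamino on a sulfonyl sulfur. Among the compounds with values here, no step between measured compounds exists to calibrate this change, and nothing in the numbers points either way. The expected step that the limit leaves unreadable from compound 2 to compound 3 is therefore set at none beyond the scatter. Compound 3 is expected to give about 15000 nM, within a range from 5000 nM to 50000 nM, and most likely to be reported again only as a limit.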

Compound 3, half-maximal inhibitory concentration: > 10000 nM
Compound 3 was reported as a limit; the forecaster's own chance of this, stated with the estimate: 80%; the middle value is on the limit's open side.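

Within the data shown here, no step from compound 2 to compound 3 can be read in this assay, since the two are reported only as limits: the limit of > 10000 nM in this assay, at which 3 of the 3 values shown sit. The compounds shown leave open whether isopropyl in place of cyclopropylamino on a sulfonyl sulfur alters inhibition at all, and how strongly any of the three compounds inhibits.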